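The source may report more compounds than this note shows. Statements on the series, on what has been measured and on what is new or still open speak of the compounds shown alone.

Measured so far:
- compound 1, `O=C(CN1CCCC1)N1CCC(NS(=O)(=O)c2cc(S(=O)(=O)c3ccccc3)ccc2C(F)(F)F)CC1`: 110 nM
- compound 2, `CC(C)(C)CC(=O)N1CCC[C@H]1C(=O)N1CCC(NS(=O)(=O)c2cc(S(=O)(=O)c3ccccc3)ccc2C(F)(F)F)CC1`: 20 nM
- compound 3, `CC(C)(C)NC(=O)N1CCC[C@H]1C(=O)N1CCC(NS(=O)(=O)c2cc(S(=O)(=O)c3ccccc3)ccc2C(F)(F)F)CC1`: 20 nM

All three share one core and differ only in the group on the carbonyl carbon attached to the piperidine nitrogen. In an assay on isolated protein for binding affinity to secreted frizzled-related protein 1 (Homo sapiens), read by fluorescence (on this read-out higher numbers stand for weaker inhibition and lower numbers for stronger inhibition), compound 1 gives 110 nM. Replacing the (pyrrolidin-1-yl)methyl there with a capped pyrrolidin-2-yl gives a 5.5-fold lower number from compound 1 to compound 2 (0.74 log units; beyond the scatter) and a 5.5-fold lower number from compound 1 to compound 3 (0.74 log units; beyond the scatter). Between the two caps there is no change at the digits printed from compound 2 to compound 3 (within the scatter). Compound 3 thus stands level with compound 2 at the digits shown, and the two together hold the lowest numbers of the three; compound 1 is furthest away.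

Compound 4, `CN1CCC[C@H]1C(=O)N1CCC(NS(=O)(=O)c2cc(S(=O)(=O)c3ccccc3)ccc2C(F)(F)F)CC1`, is not yet measured. Its difference from compound 3 is methyl in place of (tert-butyl)carbamoyl on an amine nitrogen in a ring. Among the measured compounds shown here, no measured pair carries exactly this change. What bears on it are the two steps from compound 1, which show that the cap on the pyrrolidine nitrogen, whether neopentylcarbonyl or (tert-butyl)carbamoyl, goes with the lower number, and the step from compound 2 to compound 3, which shows that the two caps are interchangeable. Compound 4 keeps the pyrrolidin-2-yl linkage of compounds 2 and 3 but loses the cap. The expectation is therefore a move back toward compound 1, but not all the way, since the (pyrrolidin-1-yl)methyl of compound 1 is also absent: an expected 3.0-fold higher number from compound 3 to compound 4 (0.48 log units; beyond the scatter) for compound 4. In this assay compound 4 is expected to give about 60 nM, estimated range 25 nM to 150 nM.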

Compound 4, half-maximal inhibitory concentration: 120 nM
The estimate for compound 4 lay 2.0-fold (0.30 log units) below the measured number; the measured number falls inside the stated range.
By their numbers in this assay, from the lowest: compounds 2 and 3 (each within the scatter of the next); then compounds 1 and 4 (each within the scatter of the next).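

In this assay, the lower numbers of compound 2 and compound 3 now trace to the cap on the amine nitrogen in the ring, not to the pyrrolidin-2-yl linkage alone: methyl in that place gives a 6.0-fold higher number from compound 3 to compound 4 (0.78 log units; beyond the scatter) and a 6.0-fold higher number from compound 2 to compound 4 (0.78 log units; beyond the scatter). With methyl as the cap, the 1-methylpyrrolidin-2-yl and the (pyrrolidin-1-yl)methyl on the carbonyl carbon cannot be told apart, at a 1.1-fold higher number from compound 1 to compound 4 (0.04 log units; within the scatter), so the linkage by itself shows no measurable benefit in this pair. No supporting measurement is available to account for the loss on going from either larger cap to methyl.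

Still open, as far as these compounds go, is which part of the neopentylcarbonyl and (tert-butyl)carbamoyl caps carries the lower number: an acetyl, a plain neopentyl with no carbonyl, or the free ring amine with no substituent would begin to separate the carbonyl from the branched alkyl end. Also open, from the compounds shown here alone, is how far the cap tolerates other ends, such as a carboxylic acid or a longer chain, and whether the mirror-image pyrrolidin-2-yl keeps the same cap dependence.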